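A few compounds are considered here, and "the series" means these few. Any claim that something is new, unique, unknown or untested is made for them only; others in the source may bear on it.

Liver enzymes clear many compounds before they can act, so early work often checks how long a compound survives them. In an ADME assay on microsomes from liver (Mus musculus) for metabolic stability, read by LC-MS, using NADPH, with stated times of 15 min and 60 min, tested at 4.6 uM (a higher number here means that the compound lasts longer, a lower number that the compound disappears faster), compound 1 `CC(C)N1CCC(c2ccc3c(c2)oc(=O)n3C(=O)NCCCCc2ccccc2)CC1` gives 1 h and compound 2 `CC(C)CNC(=O)n1c(=O)oc2c(C3CCN(C)CC3)cccc21` gives 0.5 h. Within the data shown here, these are the only two measurements so far, and they lie within the usual scatter of each other, so compound 1 cannot be ranked apart from compound 2.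

Compound 3 `CCN1CCN(c2ccc3c(c2)oc(=O)n3C(=O)NCCCCc2ccccc2)CC1` keeps the core and the side chain of compound 1. Among the measured compounds shown here, the one change is 4-ethylpiperazin-1-yl in place of 1-isopropylpiperidin-4-yl on an aromatic carbon. For the measured compounds named here, no measured pair differs in just one place, so nothing yet shows directly what such a swap does in this assay. Compound 2 differs from compound 1 in more than one place, so it offers only a rough sense of the spread.

With so little to go on, the expectation is a small drop at most, with no step beyond the scatter. The expected change is a 1.3-fold lower number from compound 1 to compound 3 (0.10 log units; within the scatter). Compound 3 is estimated at 0.8 h, with an expected range from 0.35 h to 1.8 h.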

Compound 3, half-life: < 0.0834 h
Compound 3: a limit, no number; the forecaster's own chance of this, stated with the estimate: 5%; middle value at least 9.5-fold (0.98 log units) from the limit.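

Among these compounds, this is the first pair of compounds that differ in one place, and it shows that the group on this aromatic carbon matters a great deal for survival in this assay: putting 4-ethylpiperazin-1-yl in place of 1-isopropylpiperidin-4-yl gives an at least 11-fold lower number from compound 1 to compound 3 (1.07 log units; beyond the scatter). Among the compounds shown here, the two groups look much alike on paper, each a six-membered non-aromatic ring carrying a small chain, and they differ by only one ring atom and the chain on the ring, so a swap this modest in appearance can still move the result well beyond the scatter. The reading for compound 3 is a limit of the assay, not a number: the limit of < 0.0834 h in this assay, at which 1 of the 3 values shown sits.

The swap changes the ring and its small chain together, so the pair cannot say which of the two carries the step, and 1-ethylpiperidin-4-yl or 4-isopropylpiperazin-1-yl on the same aromatic carbon would be the groups to separate them. For the compounds shown here, it also stays open whether the same swap would have a similar effect with a side chain other than the one shared by compound 1 and compound 3, such as a shorter alkyl chain.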